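The compounds below may be only part of what the source reports. "The series", "measured", "known", "first", "only" and "open" are said of these compounds alone.

Measured compounds:
Compound 2 `CCCc1cc(NNC(=O)Nc2cc(Cl)nc(Cl)c2)nc2c1c(C)nn2C`: 2360 nM
Compound 3 `CCCc1cc(NNC(=O)Nc2cc(Cl)nc(Cl)c2)nc2c1cnn2C`: 1400 nM
Compound 1 `Cc1c(Cc2ccccc2)c(NNC(=O)Nc2cc(Cl)nc(Cl)c2)nc2c1cnn2C`: 870 nM

In an assay on isolated protein for binding affinity to sphingosine 1-phosphate receptor 2 (Homo sapiens), read by surface plasmon resonance (a lower number here means tighter binding, a higher number weaker binding), compound 2 gives the highest of the three numbers. The step from compound 2 to compound 3, hydrogen in place of methyl on an aromatic carbon, was a 1.7-fold lower number from compound 2 to compound 3 (0.23 log units; within the scatter). Among the measured compounds shown here, compound 1 gives 870 nM, a lower number, but it differs from compound 2 in two places, so no single step is isolated. Compound 4 `Cc1nn(C)c2nc(NNC(=O)Nc3cc(Cl)nc(Cl)c3)cc(-c3ccco3)c12` differs from compound 2 by furan-2-yl in place of propyl on an aromatic carbon. For the measured compounds named here, no measured step touches this position, so the expectation rests only on the spread of the three numbers. Compound 4 is therefore expected to show at most a modest change, a 1.6-fold lower number from compound 2 to compound 4 (0.20 log units; within the scatter), with an estimated value of 1500 nM and a range from 500 nM to 5000 nM.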

Compound 4, dissociation constant: 6520 nM
Compound 4: middle estimate off by 4.3-fold (0.64 log units), on the low side, outside the stated range (above it).
By their numbers in this assay, from the lowest: compounds 1, 3 and 2 (each within the scatter of the next, the first and the last beyond it); then compound 4.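

With furan-2-yl in place of propyl on the aromatic carbon opposite the ring nitrogen, this assay shows a 2.8-fold higher number from compound 2 to compound 4 (0.44 log units; beyond the scatter). This shows that binding responds to the group at this position, and that this five-membered aromatic ring binds more weakly than propyl. Nothing shown here gives a reason for the change.

Still open, as far as these compounds go, is whether the weaker binding goes with the ring as such or with its oxygen. A phenyl or thiophene ring, or a longer chain such as butyl, at this position would help to separate these.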